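Compound 3 to compound 4: carbonyl swapped for sulfonyl

The compounds below may be only part of what the source reports. "The series", "measured", "known", "first", "only" and "open" are said of these compounds alone.

Measured so far in an ADME assay on L02 cells (Homo sapiens) for cytotoxicity, read by MTT assay; a higher number here means a weaker inhibitor, a lower number a stronger inhibitor (each value is a limit):
- Compound 1 `C=CC(=O)Oc1cc(/C=C/C(=O)c2ccc(OC)c3c2OC(C)(C)C=C3)ccc1OC` gives > 10000 nM as a limit
- Compound 2 `COc1ccc(/C=C/C(=O)c2ccc(OC)c3c2OC(C)(C)C=C3)cc1OC(=O)C1CC1` gives > 10000 nM as a limit
- Compound 3 `COc1cccc(C(=O)Oc2cc(/C=C/C(=O)c3ccc(OC)c4c3OC(C)(C)C=C4)ccc2OC)c1` gives > 10000 nM as a limit

Compound 3 has no exact number and stands with the other two at the limit of > 10000 nM in this assay, at which 3 of the 3 values shown sit, in the table above.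

Compound 4 `COc1ccc(/C=C/C(=O)c2ccc(OC)c3c2OC(C)(C)C=C3)cc1OS(=O)(=O)c1ccc(C)cc1` has not yet been measured. Its difference from compound 3 is (4-methylphenyl)sulfonyl in place of (3-methoxyphenyl)carbonyl on an oxygen on an aromatic ring and in words, (4-methylphenyl)sulfonyl sits in place of (3-methoxyphenyl)carbonyl on an oxygen on an aromatic ring.

The closest evidence comes from swaps of the group on the carbonyl carbon. These are a step that the two limits leave unreadable from compound 1 to compound 2 and a step that the two limits leave unreadable from compound 1 to compound 3 and also a step that the two limits leave unreadable from compound 2 to compound 3 so none of them has a size that can be read. For the measured compounds named here, no measured step replaces the carbonyl with a sulfonyl, so this change is untested. Three different groups all stayed at the limit, so no step beyond the scatter and no direction can be expected in this assay on this evidence.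

The expected step is a step that the limit leaves unreadable from compound 3 to compound 4 as a rough estimate. For compound 4 the estimated value is 15000 nM with an expected range from 8000 nM to 40000 nM and the most likely outcome is another limit.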

Compound 4, half-maximal inhibitory concentration: > 10000 nM
Compound 4: a limit, no number; the forecaster's own chance of this, stated with the estimate: 85%; the middle value does not contradict the limit.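

In this assay compound 4 gives > 10000 nM, which is a limit and not a number. Its steps from compound 1, compound 2 and compound 3 cannot be read, because all four compounds stop at the same limit: the limit of > 10000 nM in this assay, at which 4 of the 4 values shown sit.

The compounds shown leave open what exact value any of them has in this assay, and whether sulfonyl in place of carbonyl changes that value at all.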